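This account rests on a few compounds, and the source may have more. Where it says the series, first, only, none or still open, it means among the compounds named here.

Series notes. The shared core of compound 1 `COc1ccc(C2CC(c3ccc(Cl)cc3)=NN2c2ccc(-c3ccccc3)nn2)cc1` carries a chloro-substituted aryl on one carbon of the central ring; in a functional assay on MCF7 cells (Homo sapiens) for antiproliferative activity, read by MTT assay, with a stated time of 24 h (a higher number here means a weaker inhibitor, a lower number a stronger inhibitor), compound 1 gives 100000 nM. Compound 2 `COc1ccc(C2=NN(c3ccc(-c4ccccc4)nn3)C(c3ccc(Cl)cc3)C2)cc1` places the chlorophenyl on the other carbon of the same ring, and in this assay compound 2 gives 58000 nM. Compound 3 `COc1ccc(C2=NN(c3ccc(-c4ccccc4)nn3)C(c3ccc(C(F)(F)F)cc3)C2)cc1` keeps that arrangement with trifluoromethyl in place of chloro, and in this assay compound 3 gives 46800 nM. Compound 3 holds the lowest number of the three measured, but the step of a 1.2-fold lower number from compound 2 to compound 3 (0.09 log units; within the scatter) is within the scatter, so compound 3 and compound 2 cannot be told apart; only compound 1 sits beyond the scatter from compound 3.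

Compound 4 `COc1ccc(C2=NN(c3ccc(-c4ccccc4)nn3)C(c3ccc(OC)cc3)C2)cc1` is the next member: methoxy in place of trifluoromethyl on an aromatic carbon. The one measured step at this position, from compound 2 to compound 3, was within the scatter, so the position has so far shown no sensitivity in this assay. Among the measured compounds shown here, no measured step covers methoxy at this place. The expectation is therefore a step of a 1.2-fold higher number from compound 3 to compound 4 (0.07 log units; within the scatter), not beyond the scatter. Compound 4 is estimated at 55000 nM, with a range from 25000 nM to 120000 nM.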

Compound 4, half-maximal inhibitory concentration: 100000 nM
Compound 4: middle estimate off by 1.8-fold (0.26 log units), on the low side; the range from low to high includes it.
By their numbers in this assay, from the lowest: compounds 3, 2, 1 and 4 (each within the scatter of the next, the first and the last beyond it).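

Working notes on the series. In this assay the 4-substituted phenyl group no longer looks insensitive, since a 2.1-fold higher number from compound 3 to compound 4 (0.33 log units; beyond the scatter) is a modest step but the first at this position to go beyond the scatter. The comparison with chloro is less clear: a 1.7-fold higher number from compound 2 to compound 4 (0.24 log units; within the scatter) stays within the scatter, as did the earlier step from chloro to trifluoromethyl, so only trifluoromethyl and methoxy are separated, while chloro cannot be told apart from either. The reading no change at the digits printed from compound 1 to compound 4 (within the scatter) also places compound 4 level with the compound that carries the chlorophenyl on the other carbon of the central ring, so the methoxy compound shows no gain over either chloro compound in this series.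

Three groups at one position give too little to say whether the separation of trifluoromethyl from methoxy reflects a trend or only the ends of the scatter. Going by these compounds, it remains open how an amine, a carboxylic acid or a longer alkyl chain at this position would read in this assay and whether any of them would move the number beyond the scatter from compound 3 in either direction. No supporting measurement is available to explain the step from trifluoromethyl to methoxy.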